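The compounds below may be only part of what the source reports. "The series", "measured", "known", "first", "only" and "open" are said of these compounds alone.

In a physicochemical assay for lipophilicity, read by LC-MS (on this read-out higher numbers stand for higher lipophilicity and lower numbers for lower lipophilicity), compound 3 (`FC(F)(F)c1nccc(N[C@H]2CC[C@@H](Nc3ncnc4sccc34)CC2)n1`) gives 2.9, the higher of the two actual numbers, and compound 1 (`FC(F)(F)c1nccc(N[C@H]2CC[C@@H](Nc3ccncn3)CC2)n1`) gives 1.9. Compound 2 (`FC(F)(F)c1cccc(N[C@H]2CC[C@@H](Nc3ccnc(C(F)(F)F)n3)CC2)c1`) reads > 5.3, which is a limit of the assay and not a number. Compound 4 (`FC(F)(F)c1nccc(N[C@H]2CC[C@@H](Nc3ccc4nncn4n3)CC2)n1`) has not yet been measured, and it differs from compound 3 by one exchange: a group of 9 heavy atoms (5 carbon, 4 nitrogen; one five-membered aromatic ring with 3 hetero atoms, one six-membered aromatic ring with 2 hetero atoms) in place of a group of 9 heavy atoms (6 carbon, 2 nitrogen, 1 sulfur; one five-membered aromatic ring with 1 hetero atom, one six-membered aromatic ring with 2 hetero atoms), on an amine nitrogen. The sulfur leaves, and the incoming group carries more nitrogen while keeping the same number of heavy atoms. Among the measured compounds shown here, only one measured step bears on this: a number 1.00 log units higher from compound 1 to compound 3 (beyond the scatter), a modest move beyond the scatter, made when the sulfur-bearing group arrived on the amine nitrogen. That group now departs, so a move back down of similar size is expected, although this exact exchange has no measurement behind it. The expected step is a number 1.10 log units lower from compound 3 to compound 4 (beyond the scatter), which would lie beyond the scatter. For compound 4 the estimate is 1.8, with an expected range from 1.2 to 2.4.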

Compound 4, distribution coefficient: 1.7
Compound 4: middle estimate off by 0.10 log units, on the high side; the range from low to high includes it.
By their numbers in this assay, from the lowest: compounds 4 and 1 (each within the scatter of the next); then compound 3. At a limit, above all of these: compound 2.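

In this assay the groups leaving and entering on the amine nitrogen have the same count of heavy atoms, yet the exchange gives a number 1.20 log units lower from compound 3 to compound 4 (beyond the scatter) in this one pair, so the count of heavy atoms alone does not set the reading at this place. A second ring does not decide it either, as the two-ring group of compound 3 read beyond the scatter of compound 1, while the other two-ring group gives a number 0.20 log units lower from compound 1 to compound 4 (within the scatter) and stays within it. Nothing measured here accounts for the difference between the two groups.

Going by these compounds, the exchange removes the sulfur and adds nitrogen at once, so the share of each in the step stays open. A two-ring group with oxygen in place of the sulfur could separate them, and a morpholine on this nitrogen would test a non-aromatic ring.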